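A few compounds are considered here, and "the series" means these few. Any claim that something is new, unique, unknown or untested is made for them only; others in the source may bear on it.

Measured compounds:
- compound 1, `Clc1nc(-c2cccs2)c2ncn(Cc3ccccc3)c2n1`: > 10 ug/mL
- compound 2, `c1ccc(Cn2cnc3c(-c4ccco4)ncnc32)cc1`: 8.6 ug/mL

Within the data shown here, in a functional assay on Vero cells (Chlorocebus sabaeus) for inhibition (a higher number here means a weaker inhibitor, a lower number a stronger inhibitor), compound 2 gives 8.6 ug/mL; this is the only numerical value in the set. For compound 1 the assay reports only > 10 ug/mL, which is a limit and not a number; compound 1 thus sits at the limit of > 10 ug/mL in this assay, at which 1 of the 2 values shown sits. Among the measured compounds shown here, no pair of measured compounds differs in a single place, so no measured step is available.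

Compound 3, `Clc1nc(-c2ccco2)c2ncn(Cc3ccccc3)c2n1`, is not yet measured. It differs from compound 2 by chloro in place of hydrogen on an aromatic carbon. Compound 1 also carries a chloro group on its core and gave only a limit, while compound 2, without it, gave a number; the two compounds differ elsewhere as well, so this is an observation on two values and not a step.

For this assay a small shift towards weaker inhibition is expected from compound 2 to compound 3, a 1.4-fold higher number from compound 2 to compound 3 (0.14 log units; within the scatter), lying at the edge of the scatter. Compound 3 is therefore estimated at 12 ug/mL, with a range of 5 ug/mL to 30 ug/mL, and it may well come back as a limit.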

Compound 3, half-maximal inhibitory concentration: 8.1 ug/mL
Estimate against measurement, compound 3: 1.5-fold (0.17 log units) above, and the stated range covers the measured number.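

In this assay, among these compounds, chloro in place of hydrogen on an aromatic carbon between two ring nitrogen atoms gives a 1.1-fold lower number from compound 2 to compound 3 (0.03 log units; within the scatter), so this position carries the chloro group with the two values inside the scatter of each other, a direct reading that the earlier compounds, which differ in more than one place, could not give. Among the compounds shown here, with the chloro group held constant, furan-2-yl in place of thiophen-2-yl gives an at least 1.2-fold lower number from compound 1 to compound 3 (0.09 log units; that floor lies within the scatter), which is the first step at this second position, although it sets only a floor that lies within the scatter and does not fix the true size of the exchange. The value for compound 1 in this assay is a limit and not a number: the limit of > 10 ug/mL in this assay, at which 1 of the 3 values shown sits.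

As far as these compounds go, whether an amine or a methoxy group in place of the chloro group would move the number beyond the scatter remains open. Also open, from the compounds shown here alone, are the effect of a phenyl or pyridyl group in place of furan-2-yl and that of any substituent on the benzyl group.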